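The compounds below may be only part of what the source reports. "The series", "measured", "known", "first", "only" and "open" are said of these compounds alone.

In a functional assay on HepG2 cells (Homo sapiens) for cytotoxicity, read by MTT assay, with a stated time of 72 h (on this read-out higher numbers stand for weaker inhibition and lower numbers for stronger inhibition), compound 2 `C/C(=N\NC(=O)c1ccncc1)C(=O)Nc1ccc(Cl)cc1` is known only through a limit of the assay. In this assay compound 2 gives > 50000 nM, which is a limit and not a number. Its neighbour compound 1 `C/C(=N\NC(=O)c1ccncc1)C(=O)Nc1cccc(Cl)c1` is described the same way. In this assay compound 1 gives > 50000 nM, again a limit. Among the compounds with values here, the step that the two limits leave unreadable from compound 1 to compound 2 is therefore unreadable, and the only evidence on the series is the limit of > 50000 nM in this assay, at which 2 of the 2 values shown sit. Compound 3 `C/C(=N\NC(=O)c1ccncc1)C(=O)Nc1ccc(Cl)c(Cl)c1` has not yet been measured; it differs from compound 2 by chloro in place of hydrogen on an aromatic carbon. Within the data shown here, no measured step concerns a change of this kind, and none yields a readable size, so the two limits give no guidance on the direction or magnitude to expect in this assay. Compound 3 is expected to give 60000 nM in this assay, within a range from 20000 nM to 200000 nM, and most probably only a limit again. The expected step that the limit leaves unreadable from compound 2 to compound 3 is accordingly estimated to be small.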

Compound 3, half-maximal inhibitory concentration: > 50000 nM
Compound 3: only a limit was reported (the forecaster's own chance of this, stated with the estimate: 75%); the middle value is on the limit's open side.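

In this assay compound 3 gives > 50000 nM, which is a limit and not a number. Within the data shown here, no step to compound 3 from compound 2 or compound 1 can be read. The compounds shown leave open what chloro in place of hydrogen on an aromatic carbon does to the read-out, since all they offer is this: the limit of > 50000 nM in this assay, at which 3 of the 3 values shown sit.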